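This account rests on a few compounds, and the source may have more. Where it says the series, first, only, none or still open, it means among the compounds named here.

In an ADME assay on MT4 cells (Homo sapiens) for cytotoxicity, read by MTT assay (on this read-out lower numbers stand for higher toxicity in this test and higher numbers for lower toxicity in this test), compound 3 `COc1cccc(F)c1CNC(=O)c1[nH]c2ccc(Cl)cc2c1S(=O)(=O)c1cc(C)cc(C)c1` gives > 49900 nM, which is a limit and not a number. Compound 2 `Cc1cc(C)cc(S(=O)(=O)c2c(C(=O)NCc3cccc(N)c3)[nH]c3ccc(Cl)cc23)c1` gives > 53400 nM, which is also a limit. Among the compounds with values here, compound 1 `Cc1cc(C)cc(S(=O)(=O)c2c(C(=O)NCC(=O)NC(C)c3ccccc3)[nH]c3ccc(Cl)cc23)c1` is the only one with a true number, 29400 nM.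

The next structure is compound 4 `Cc1cc(C)cc(S(=O)(=O)c2c(C(=O)Nc3ccnc(C#N)c3)[nH]c3ccc(Cl)cc23)c1`, which keeps the shared core but changes the group on the amide-type nitrogen: 2-cyanopyridin-4-yl in place of 2-fluoro-6-methoxybenzyl on an amide-type nitrogen. So 2-cyanopyridin-4-yl stands in place of 2-fluoro-6-methoxybenzyl.

The measured steps that bear on this also exchange the group carried on the amide side. These are an at least 1.8-fold higher number from compound 1 to compound 2 (0.25 log units; that floor lies within the scatter) and an at least 1.6-fold higher number from compound 1 to compound 3 (0.22 log units; that floor lies within the scatter), while the third is a step that the two limits leave unreadable from compound 2 to compound 3. Neither readable step goes beyond the scatter, so no step beyond the scatter is expected in this assay, although neither group exchanged in those steps resembles 2-cyanopyridin-4-yl. The expected change is an at least 1.4-fold lower number from compound 3 to compound 4 (0.15 log units; that floor lies within the scatter). For compound 4 the estimate is 35000 nM, with an expected range from 12000 nM to 60000 nM.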

Compound 4, half-maximal cytotoxic concentration: 6840 nM
Beside the measured number, compound 4's estimate is 5.1-fold (0.71 log units) above it, and the stated range ends above it.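

Within the data shown here, compound 4 is the first case here where a change to the group on the amide-type nitrogen moves the number in this assay beyond the scatter: putting in 2-cyanopyridin-4-yl gives an at least 7.2-fold lower number from compound 3 to compound 4 (0.86 log units; beyond the scatter) and an at least 7.8-fold lower number from compound 2 to compound 4 (0.89 log units; beyond the scatter) as two floors set by limits. Measured from a true number rather than a limit, the change still gives a 4.3-fold lower number from compound 1 to compound 4 (0.63 log units; beyond the scatter) so the fall toward higher toxicity in this test does not rest on limits alone. Nothing measured here gives a reason for this fall.

The compounds shown leave open which part of the exchange carries the fall: the ring nitrogen, the nitrile, or the loss of the benzyl chain carbon. A plain phenyl on the amide-type nitrogen or a pyridin-4-ylmethyl group would help separate these.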